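The source may hold more compounds than are shown below. What is called first, only, known or untested is meant among the compounds shown, and "the series" means these compounds.

Measured so far, in an assay for inhibition of MAP kinase-interacting serine/threonine-protein kinase 2 (Homo sapiens), read by luminescence and ADP-Glo, with a stated time of 2 h; a lower number here means a stronger inhibitor, a higher number a weaker inhibitor:

compound 1, `Nc1n[nH]c2cc(-c3ccc(=O)n(Cc4ccccc4)c3)ccc12`: 32 nM
compound 2, `NC(=O)c1ccccc1Cn1cc(-c2ccc3cn[nH]c3c2)ccc1=O`: 340 nM
compound 3, `Cn1ncc2ccc(-c3ccc(=O)n(Cc4ccccc4)c3)cc21`: > 2000 nM

Compound 1 has the lowest of the two numbers in this assay. Compound 2 sits well beyond the scatter from compound 1, on the weaker side. For compound 3 the value is a limit of this assay rather than a number, (the limit of > 2000 nM in this assay, at which 1 of the 3 values shown sits); it only says that compound 3 did not reach a measurable inhibition within the range of this assay.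

Not yet measured is compound 4, `Nc1n[nH]c2cc(-c3ccc(=O)n(Cc4cccc(F)c4)c3)ccc12`. It differs from compound 1 in one place: fluoro in place of hydrogen on an aromatic carbon. The change is small and sits on the benzyl group, away from the shared core of compound 1 and compound 4. The shared core is kept unchanged, and the benzyl group is kept, only turned into 3-fluorobenzyl. Within the data shown here, no measured pair reports the effect of a fluoro on this group, so the expectation rests on the size of the change alone. The expected step from compound 1 to compound 4 is a 1.1-fold lower number from compound 1 to compound 4 (0.03 log units; within the scatter), within the scatter in either direction. Compound 4 is therefore expected to give about 30 nM in this assay, with a range from 12 nM to 80 nM.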

Compound 4, half-maximal inhibitory concentration: 5 nM
For compound 4 the middle estimate is 6.0-fold (0.78 log units) above the measured one, and the stated range ends above it.
By their numbers in this assay, from the lowest: compound 4; then compound 1; then compound 2. At a limit, above all of these: compound 3.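

Fluoro in place of hydrogen on the benzyl group gives a 6.4-fold lower number from compound 1 to compound 4 (0.81 log units; beyond the scatter) in this assay and so shows that this aromatic ring, away from the shared core, is a place where a single heavy atom can move the number beyond the scatter. Among these compounds, the earlier compounds held no pair differing in one place, so this is the first reading of this position, and it rests on this one pair alone. Nothing measured here bears on why the 3-fluorobenzyl group gives the lower number.

Still open, on these data alone, is whether the step belongs to fluoro itself or would also come with a chloro, methyl or methoxy group on the same carbon. Also open, as far as these compounds go, is how fluoro behaves on the other carbons of this ring, and whether a larger group such as an amine or a carboxylic acid fits there.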